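From thiomorpholin-4-yl to pyrrolidin-1-yl on the thiocarbonyl carbon

The source may report more compounds than this note shows. Statements on the series, on what has been measured and on what is new or still open speak of the compounds shown alone.

Compound 1 `N/C(=N\NC(=S)N1CCSCC1)c1ccccn1`: 87.8%
Compound 2 `N/C(=N\NC(=S)N1CCSCC1)c1ccc(F)cn1`: 83.2%

Among the measured compounds shown here, in a functional assay on A-375 cells (Homo sapiens) for cytotoxicity, read by MTT assay, with a stated time of 72 h, tested at 100 uM (a higher number here means more inhibition of growth at the concentration tested, a lower number less inhibition of growth), compound 1 gives 87.8%, the higher of the two numbers measured so far. Compound 2 lies close by, and the step of a number 4.6 percentage points lower from compound 1 to compound 2 (within the scatter) stays within the scatter, so the two values show no real difference.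

Compound 3 `N/C(=N\NC(=S)N1CCCC1)c1ccccn1` has not been measured. It differs from compound 1 only by pyrrolidin-1-yl in place of thiomorpholin-4-yl on a thiocarbonyl carbon. For the measured compounds named here, no measured step touches this part of the molecule; the single known step concerns a fluoro on the aromatic ring and so says nothing direct about the ring on the thiocarbonyl carbon. Going by the values given here, the only guide is that both measured compounds sit high in this assay. A modest drop, not clearly beyond the scatter, is therefore the expectation, giving an estimated step of a number 7.8 percentage points lower from compound 1 to compound 3 (within the scatter). Compound 3 is thus expected to reach about 80%, within a range of 55% to 95%.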

Compound 3, percent growth inhibition at one concentration: 87.8%
Estimate against measurement, compound 3: 7.8 percentage points below; the range from low to high includes it.
By their numbers in this assay, from the lowest: compounds 2, 1 and 3 (each within the scatter of the next).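

Replacing thiomorpholin-4-yl with pyrrolidin-1-yl on the thiocarbonyl carbon gives no change at the digits printed from compound 1 to compound 3 (within the scatter) in this assay. The earlier step concerned only a fluoro on the aromatic ring, whereas this one shows that, at this position, a five-membered ring without sulfur gives the same reading as the six-membered ring that holds sulfur. No measurement available here offers an explanation for this result.

Going by these compounds, it remains open whether the same reading would hold with an open-chain group such as diethylamino on the thiocarbonyl carbon, or with a morpholin-4-yl or piperazin-1-yl ring there. Also open, on these data alone, is what pyrrolidin-1-yl would give when combined with the fluoro on the aromatic ring.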